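The source may report more compounds than this note shows. Statements on the series, on what has been measured and on what is new or still open speak of the compounds shown alone.

Measured compounds in this series:

Compound 1 `COc1ccc(/C(C)=N/Nc2nc3ccccc3nc2Cc2ccccc2)cc1` — in an assay on isolated protein for inhibition of Amine oxidase [flavin-containing] A (Homo sapiens), read by spectrophotometry (a lower number here means a stronger inhibitor, a higher number a weaker inhibitor), compound 1 gives 89 nM
Compound 2 `C/C(=N\Nc1nc2ccccc2nc1Cc1ccccc1)c1ccccc1` — in this assay compound 2 gives 79 nM

Among the compounds with values here, compound 2 stands at one end of the two numbers so far, but the only step to it, a 1.1-fold lower number from compound 1 to compound 2 (0.05 log units; within the scatter), lies within the scatter, so compound 1 and compound 2 stand level in this assay and no order between them can be claimed.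

Compound 3 `C/C(=N\Nc1nc2ccccc2nc1Cc1ccccc1)c1ccc(O)cc1` has not yet been measured in this assay. It differs from compound 2 by hydroxy in place of hydrogen on an aromatic carbon. Within the data shown here, the one measured step that touches this same aromatic carbon is a 1.1-fold lower number from compound 1 to compound 2 (0.05 log units; within the scatter), and it was within the scatter. Among the measured compounds shown here, on that basis the change to compound 3 is expected to leave the number within the scatter as well; no compound bearing a hydroxy group has been measured, so the expectation rests on that single step. For compound 3 the expected step is a 1.1-fold lower number from compound 2 to compound 3 (0.05 log units; within the scatter). The estimate for compound 3 in this assay is 70 nM, with a range from 30 nM to 170 nM.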

Compound 3, half-maximal inhibitory concentration: 2.8 nM
Compound 3: the middle estimate sits 25-fold (1.40 log units) above what was measured; measured number outside the range, below it.
By their numbers in this assay, from the lowest: compound 3; then compounds 2 and 1 (each within the scatter of the next).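

Notes on the aromatic carbon para to a large group: in this assay the group on this carbon now matters, since hydroxy in place of hydrogen gives a 28-fold lower number from compound 2 to compound 3 (1.45 log units; beyond the scatter) and sets this change apart from the methoxy and hydrogen pair, where a 1.1-fold lower number from compound 1 to compound 2 (0.05 log units; within the scatter) showed no separation. Taking only the methyl off the oxygen gives a 32-fold lower number from compound 1 to compound 3 (1.50 log units; beyond the scatter) and so separates hydroxy from methoxy at one and the same carbon, which means that an oxygen on this carbon does not by itself go with the lower number among these three compounds. No measurement on hand bears on why hydroxy stands apart from methoxy and hydrogen here.

Open, from the compounds shown here alone, is whether the large step is specific to hydroxy, or whether another group on this carbon, such as an amine or a hydroxymethyl group, would give a comparable step. Also open, going by these compounds, is whether hydroxy keeps this effect on another carbon of the same ring, or with other groups in place of the methyl on the imine carbon of the shared core.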